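Vinyl in Place of Chloro on the Exocyclic Double Bond

The source may report more compounds than this note shows. Statements on the series, on what has been measured and on what is new or still open speak of the compounds shown alone.

Measured compounds:
- Compound 1, `C/C=C1\C=C(C)C2(CC2)C(C)(O)C1=O`, gives 4 nM in a functional assay on A-375 cells (Homo sapiens) for antiproliferative activity; on this read-out lower numbers stand for stronger inhibition and higher numbers for weaker inhibition.
- Compound 2, `CC1=C/C(=C\c2ccccc2)C(=O)C(C)(O)C12CC2`, gives > 10000 nM in this assay.
- Compound 3, `CC1=C/C(=C\Cl)C(=O)C(C)(O)C12CC2`, gives 1000 nM in this assay.

Three compounds share one core and differ only in the group on a double-bonded chain carbon bound to a double-bonded ring carbon. Compound 1 carries a methyl there and gives the lowest number. Compound 2 carries a phenyl, and its value is a limit of the assay rather than a number (the limit of > 10000 nM in this assay, at which 1 of the 3 values shown sits). Compound 3 carries a chloro and, among the two numbers actually measured, stands highest: a 250-fold higher number from compound 1 to compound 3 (2.40 log units; beyond the scatter), while an at least 10-fold lower number from compound 2 to compound 3 (1.00 log units; beyond the scatter).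

Compound 4, `C=C/C=C1\C=C(C)C2(CC2)C(C)(O)C1=O`, is not yet measured. It differs from compound 3 in one place: vinyl in place of chloro on a double-bonded chain carbon bound to a double-bonded ring carbon. The measured steps show that a methyl here is far better than a chloro or a phenyl, with the phenyl worst. A vinyl is carbon-based like the methyl but larger, closer in bulk to the chloro than to the methyl and smaller than the phenyl. On that basis the expected step is a 3.3-fold lower number from compound 3 to compound 4 (0.52 log units; beyond the scatter), a moderate improvement at most, staying well short of compound 1. Compound 4 is therefore expected to give about 300 nM in this assay, somewhere between 30 nM and 3000 nM.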

Compound 4, half-maximal inhibitory concentration: 18 nM
The estimate for compound 4 lay 17-fold (1.22 log units) above the measured number, and the stated range ends above it.
By their numbers in this assay, from the lowest: compound 1; then compound 4; then compound 3. At a limit, above all of these: compound 2.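

In this assay, the position turns out to accept more than the methyl alone: the step of vinyl in place of chloro is a 56-fold lower number from compound 3 to compound 4 (1.74 log units; beyond the scatter), which covers most of the distance that separated compound 3 from compound 1. Vinyl is still not equal to methyl, with a 4.5-fold higher number from compound 1 to compound 4 (0.65 log units; beyond the scatter), but that step is modest, so a group of 2 heavy atoms with a double bond keeps much of the activity, and heavy-atom count alone does not set the order, as chloro has 1 heavy atom and yet gives the higher number. Phenyl stays far behind, with an at least 550-fold lower number from compound 2 to compound 4 (2.74 log units; beyond the scatter), and that step is only a bound, its starting value being a limit of the assay and not a number: the limit of > 10000 nM in this assay, at which 1 of the 4 values shown sits.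

The compounds shown leave open whether the double bond of the vinyl matters or only its carbons, and an ethyl at this place would separate the two. How far the position stretches is also unknown, and a longer chain or an amine there would begin to answer that.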